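The source may report more compounds than this note shows. Statements on the series, on what has been measured and on what is new or still open speak of the compounds shown alone.

Measured so far in a functional assay on T47D cells (Homo sapiens) for cytotoxicity, read by colorimetric assay and MTT assay; a higher number here means a weaker inhibitor, a lower number a stronger inhibitor:
Compound 1 `COc1cc(OC)c2cc(-c3ccccc3)c(O)nc2c1`: 10000 nM
Compound 2 `COc1ccc(-c2cc3cccc(OC)c3nc2O)cc1`: 10000 nM
Compound 3 `CCN(CC)C(=O)Cn1c(=O)c(-c2ccc(OC)cc2)cc2c(OC)cc(OC)cc21`: 10000 nM

For the measured compounds named here, compound 3, at 10000 nM, stands level with compound 1 and compound 2, so these three values set no order among the compounds. Compound 4 `COC(=O)CCn1c(=O)c(-c2ccc(OC)cc2)cc2c(OC)cc(OC)cc21` keeps the shared core of compound 3 and differs in one place, on a saturated chain carbon bound to an aromatic nitrogen: (methoxycarbonyl)methyl in place of diethylcarbamoyl on a saturated chain carbon bound to an aromatic nitrogen. Cut one bond further out, the same difference reads (diethylcarbamoyl)methyl to 2-(methoxycarbonyl)ethyl. Going by the values given here, no pair of measured compounds differs in one place, so the data offer no measured step by which to judge this change. With compound 3 at 10000 nM as the closest reference, no change beyond the scatter is expected in this assay, although a somewhat stronger result cannot be ruled out. The estimated 1.1-fold lower number from compound 3 to compound 4 (0.05 log units; within the scatter) is therefore small. The estimated value for compound 4 is 9000 nM, with an expected range of 3000 nM to 15000 nM.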

Compound 4, half-maximal inhibitory concentration: 10000 nM
The estimate for compound 4 lay 1.1-fold (0.05 log units) below the measured number, within the range that was stated.
By their numbers in this assay, from the lowest: compounds 1, 2, 3 and 4 (each within the scatter of the next).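

In this assay, putting (methoxycarbonyl)methyl in place of diethylcarbamoyl on a saturated chain carbon bound to an aromatic nitrogen gives no change at the digits printed from compound 3 to compound 4 (within the scatter). For the compounds shown here, this is the first measured step, and it shows that this change at this position leaves the result within the scatter, with the ester-bearing chain reading like the amide-bearing one. No measurement shown bears on why the two chains read alike.

The compounds shown leave open whether a carboxylic acid or an amine at the end of this chain, or a longer chain, would shift the number in this assay. With compound 1, compound 2, compound 3 and compound 4 all printing the same value, they also leave open which changes, if any, would move a compound away from it.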